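A few compounds are considered here, and "the series" means these few. Any claim that something is new, unique, unknown or untested is made for them only; others in the source may bear on it.

Working notes on the series in an assay on isolated protein for inhibition of serine/threonine-protein kinase Chk2 (Homo sapiens), read by mobility shift assay, tested at 30 uM; a lower number here means less inhibition, a higher number more inhibition at the concentration tested (going by the name of the read-out).

Compound 1 `Cc1cc2c(c(N)nn2C)c(=O)[nH]1` gives 3%. Compound 2 `Cn1nc(N)c2c(=O)[nH]c(-c3ccccc3)cc21` gives 16%. Compound 3 `Cc1cc2nc(-c3ccccc3)nc(N)c2c(=O)[nH]1` gives 4%. The difference between the core of compound 2 and the core of compound 3 is not broken down here.

One structural change is measured within the set: compound 2 and compound 1 differ by methyl in place of phenyl on an aromatic carbon and the step is a number 13 percentage points lower from compound 2 to compound 1 (beyond the scatter).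

Compound 4 `Cc1nc(N)c2c(=O)[nH]c(C)cc2n1` is not yet measured. It differs from compound 3 by methyl in place of phenyl on an aromatic carbon. This is the same kind of change as that from compound 2 to compound 1, not the same: in compound 3 the place is on a six-membered aromatic ring with 2 nitrogen, between two ring nitrogen atoms and meta to an amino group, whereas in compound 2 the place is on a ring with 1 nitrogen, next to the ring nitrogen and meta to a group of 1 heavy atom.

For compound 4 in this assay the step from compound 3 is expected to be a number 2 percentage points lower from compound 3 to compound 4 (within the scatter), set beside the measured step from compound 2 to compound 1. The expectation of a small step rests on compound 3 already giving 4%, which leaves little room for a comparable fall, and on compound 1 giving 3% after the same kind of change. Compound 4 is therefore estimated at 2%, within a range from -5% to 10%.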

Compound 4, a percentage reported as inhibition, at one concentration (the size of the read-out at that concentration, not a potency): 5%
For compound 4 the middle estimate is 3 percentage points below the measured one, and the stated range covers the measured number.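

In this assay, the step for methyl in place of phenyl on an aromatic carbon is a number 1 percentage points higher from compound 3 to compound 4 (within the scatter), while the same change on the other core is a number 13 percentage points lower from compound 2 to compound 1 (beyond the scatter). Set side by side, the two steps cannot be told apart: the same change on two cores in this assay, a number 13 percentage points lower (beyond the scatter) from compound 2 to compound 1 and a number 1 percentage points higher (within the scatter) from compound 3 to compound 4, 14 percentage points apart, within the scatter of two such steps

Going by these compounds alone, this shows that the series gives no measured sign that the core alters the outcome of this change, but it does not show that the change carries over from one core to the other, since only the step on the core of compound 2 lies beyond the scatter, and compound 3, at 4%, has little room for a comparable fall. With just two pairs, and with inhibition low at the concentration tested on both sides of the new step, the comparison can neither confirm nor rule out a dependence on the core.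

The compounds shown leave open what other groups do at this place on either core, for example an amine, a carboxylic acid or a longer alkyl chain in place of the phenyl or methyl. They also leave open whether a phenyl carrying a substituent such as an amine would raise inhibition on either core.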